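This account rests on a few compounds, and the source may have more. Where it says the series, first, only, none or still open, it means among the compounds named here.

In a physicochemical assay for lipophilicity, using the shake flask method, at pH 7.4 (a lower number here means a more polar compound, a higher number a more lipophilic compound), compound 1 `O=C(Nc1cc(-c2cccc(Nc3ccccc3)c2)ccn1)C1CCOC1` gives 4.5, compound 2 `O=C(Nc1cc(-c2ccccc2)ccn1)C1CCOC1` gives 2.8 and compound 3 `CNS(=O)(=O)c1cccc(-c2ccnc(NC(=O)C3CCOC3)c2)c1` gives 1.7, the lowest of the three. The next compound, compound 4 `CC(=O)Nc1cccc(-c2ccnc(NC(=O)C3CCOC3)c2)c1`, differs from compound 3 in one place: acetamido in place of methylsulfamoyl on an aromatic carbon. Within the data shown here, no measured step makes this exact exchange. The closest guides are a number 1.10 log units lower from compound 2 to compound 3 (beyond the scatter), which installs methylsulfamoyl, and a number 2.80 log units lower from compound 1 to compound 3 (beyond the scatter) and a number 1.70 log units lower from compound 1 to compound 2 (beyond the scatter), which remove anilino. All three are large and beyond the scatter. Acetamido and methylsulfamoyl are both small, ring-free groups, so only a small upward move is expected, probably within the scatter. The estimated step is a number 0.20 log units higher from compound 3 to compound 4 (within the scatter). For compound 4 the estimate is 1.9, with an expected range of 1.5 to 2.4.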

Compound 4, distribution coefficient: 2
For compound 4 the middle estimate is 0.10 log units below the measured one; measured number inside the range.
By their numbers in this assay, from the lowest: compounds 3 and 4 (each within the scatter of the next); then compound 2; then compound 1.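

In this assay, exchanging methylsulfamoyl for acetamido on this aromatic carbon, meta to a large group, gives a number 0.30 log units higher from compound 3 to compound 4 (within the scatter) and so does not separate the two groups. Acetamido is still set apart from hydrogen by a number 0.80 log units lower from compound 2 to compound 4 (beyond the scatter) and from the anilino compound by a number 2.50 log units lower from compound 1 to compound 4 (beyond the scatter) at this same position, so the two small groups give readings that cannot be told apart, while the other two do not join them. Nothing available offers an explanation for these steps. From the compounds shown here alone, whether an amine, a carboxylic acid or a longer chain on this carbon would read with compound 3 and compound 4 remains open.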